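Working notes: ethoxy for morpholin-4-yl at the carbonyl

A few compounds are considered here, and "the series" means these few. Any claim that something is new, unique, unknown or untested is made for them only; others in the source may bear on it.

Compound 1 `O=C(O)/C=C/c1ccncc1-c1ccc2cc[nH]c2c1` — in a functional assay on A549 cells (Homo sapiens) for inhibition, read by sulforhodamine B assay, with a stated time of 72 h (a higher number here means a weaker inhibitor of growth, a lower number a stronger inhibitor of growth), compound 1 gives only a limit of the assay, > 10000 nM.
Compound 2 `COC1CN(C(=O)/C=C/c2ccncc2-c2ccc3ccccc3c2)C1` — in this assay compound 2 gives only a limit, > 10000 nM.
Compound 3 `O=C(/C=C/c1ccncc1-c1ccc2cc[nH]c2c1)N1CCOCC1` — in this assay compound 3 gives only a limit, > 10000 nM.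

Compound 3 thus sits at the limit of > 10000 nM in this assay, at which 3 of the 3 values shown sit, as do the other two measured compounds, and no number separates any of them. Compound 4 `CCOC(=O)/C=C/c1ccncc1-c1ccc2cc[nH]c2c1` differs from compound 3 by ethoxy in place of morpholin-4-yl on a carbonyl carbon. Going by the values given here, the only measured step at the carbonyl carbon, a step that the two limits leave unreadable from compound 1 to compound 3, runs between two limits and has no readable size. Among the compounds with values here, no measured step bears on ethoxy entering in place of morpholin-4-yl, so no direction beyond the scatter is expected. Compound 4 is expected to remain at the limit, with the estimated step that the limit leaves unreadable from compound 3 to compound 4 being nominal only. The estimate for compound 4 is 20000 nM, ranging from 8000 nM to 60000 nM.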

Compound 4, concentration for 50% growth inhibition: 5740 nM
Beside the measured number, compound 4's estimate is 3.5-fold (0.54 log units) above it, and the stated range ends above it.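

In this assay compound 4 alone gives a number, so the carbonyl carbon can carry a group that brings a value inside the assay's range, while the others remain at a limit: the limit of > 10000 nM in this assay, at which 3 of the 4 values shown sit.
Ethoxy in place of morpholin-4-yl gives an at least 1.7-fold lower number from compound 3 to compound 4 (0.24 log units; that floor lies within the scatter) and ethyl in place of hydrogen on the oxygen gives an at least 1.7-fold lower number from compound 1 to compound 4 (0.24 log units; that floor lies within the scatter), both floors rather than full sizes.
The step between the two limits cannot be read.

From the compounds shown here alone, the true size of either step remains open. So does whether a longer chain such as propoxy, or an amine such as dimethylamino, on this carbonyl carbon would give a number or a limit.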